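Three Inactive Analogues and an Untested Trimethoxy Variant

This account rests on a few compounds, and the source may have more. Where it says the series, first, only, none or still open, it means among the compounds named here.

Compound 1 `Oc1ccccc1CNc1ncnc2c1ncn2C1CCCCO1`, compound 2 `COc1cccc(CNc2ncnc3c2ncn3C2CCCCO2)c1O` and compound 3 `COc1cccc(OC)c1CNc1ncnc2c1ncn2C1CCCCO1` share a core and differ only in the groups carried on one six-membered aromatic ring of carbon only. All three were tested in an ADME assay on BJ cells (Homo sapiens) for cytotoxicity, read by MTT assay, with a stated time of 72 h; on this read-out lower numbers stand for stronger inhibition and higher numbers for weaker inhibition. In this assay compound 1 gives > 100000 nM, which is a limit of the assay and not a number. Compound 2 likewise gives > 100000 nM, also a limit. Compound 3 gives > 100000 nM, again a limit.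

The change from compound 1 to compound 2 is methoxy in place of hydrogen on an aromatic carbon. The size of the step that the two limits leave unreadable from compound 1 to compound 2 cannot be read because the limit of > 100000 nM in this assay, at which 3 of the 3 values shown sit, covers both ends of the pair. The difference between the cores of compound 1 and compound 3 is not broken down here.

Compound 4 `COc1cc(OC)c(CNc2ncnc3c2ncn3C2CCCCO2)c(OC)c1` has not yet been tested. It differs from compound 3 by methoxy in place of hydrogen on an aromatic carbon. This is the same kind of change as that from compound 1 to compound 2, but not the same: in compound 2 the entering methoxy sits ortho to a hydroxy group and meta to a large group, whereas in compound 4 it sits meta to two methoxy groups and para to a large group.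

Measured against compound 3, the expected step is a step that the limit leaves unreadable from compound 3 to compound 4, which rests on the fact that compound 1, compound 2 and compound 3 all sit at the limit of > 100000 nM in this assay, at which 3 of the 3 values shown sit. In this assay compound 4 is therefore expected to give about 150000 nM, most likely reported again only as a limit, with a range estimated from 60000 nM to 400000 nM.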

Compound 4, half-maximal inhibitory concentration: > 50000 nM
Compound 4: no number, only a limit (the forecaster's own chance of this, stated with the estimate: 85%); the middle value lies beyond the limit too.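

In this assay compound 4 gives > 50000 nM, which is a limit of the assay and not a number. Among these compounds, no size can be read for the step from compound 3 to compound 4, so this pair adds no new step. The compounds shown leave open where the true values of all four lie, and whether methoxy in place of hydrogen on an aromatic carbon changes the read-out at all.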